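From methoxy to amino on compound 1

A few compounds are considered here, and "the series" means these few. Any claim that something is new, unique, unknown or untested is made for them only; others in the source may bear on it.

- Compound 1 `COc1ccc(/C=C/[C@@](C)(/C=C/c2ccc(O)cc2)CCC=C(C)C)cc1`: 20%
- Compound 2 `COc1ccc(/C=C/[C@@](C)(/C=C/c2ccc(O)cc2)CCC=C(C)C)cc1C=O`: 33%
- Compound 3 `COc1ccc(/C=C/[C@](C)(/C=C/c2ccc(O)cc2)CCC=C(C)C)cc1`: 67%

In a functional assay on OVCAR-5 cells (Homo sapiens) for inhibition, with a stated time of 48 h, tested at 50 uM (a higher number here means more inhibition of growth at the concentration tested, a lower number less inhibition of growth), compound 1 gives 20%, the lowest of the three numbers. Compound 4 `CC(C)=CCC[C@@](C)(/C=C/c1ccc(N)cc1)/C=C/c1ccc(O)cc1` keeps the core of compound 1 but changes one group: amino in place of methoxy on an aromatic carbon. Among the measured compounds shown here, no measured step makes this exact change. The closest is a number 13 percentage points higher from compound 1 to compound 2 (beyond the scatter), where formyl replaces hydrogen on an aromatic carbon. The larger a number 47 percentage points higher from compound 1 to compound 3 (beyond the scatter) rests on (the fact that compounds 1 and 3 differ only in the configuration as drawn), and configuration is not what changes here. A similarly modest rise is therefore expected from compound 2 at 33%, though this single step gives weak support. Compound 4 is estimated at 30%, with an expected range from 12% to 55%. The expected change is a number 10 percentage points higher from compound 1 to compound 4 (within the scatter).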

Compound 4, percent growth inhibition at one concentration: 16%
Estimate against measurement, compound 4: 14 percentage points above; the range from low to high includes it.
By their numbers in this assay, from the lowest: compounds 4 and 1 (each within the scatter of the next); then compound 2; then compound 3.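

The change from 4-methoxyphenyl to 4-aminophenyl gives a number 4 percentage points lower from compound 1 to compound 4 (within the scatter) in this assay. At this position, then, a hydrogen-bond donor can enter and the methoxy group can leave without a step beyond the scatter, at least on the core of compound 1 with its configuration as drawn. Nothing measured here accounts for this result. The compounds shown leave open whether a dimethylamino group or an acetamide in the same place would move the number beyond the scatter, and whether amino would behave alike in the configuration of compound 3.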